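The source may hold more compounds than are shown below. What is called first, only, known or untested is meant among the compounds shown, and "the series" means these compounds.

Compound 2 `Cc1cccc(-n2cnc3cc(C(=O)N4CCCC4)ccc32)c1` is examined in an assay on isolated protein for inhibition of 15-hydroxyprostaglandin dehydrogenase [NAD(+)] (Homo sapiens), read by fluorescence, with a stated time of 15 min (on this read-out lower numbers stand for stronger inhibition and higher numbers for weaker inhibition), where compound 2 gives 383 nM. Among the two numbers so far it is the higher one; the only neighbour, compound 1 `Cc1cccc(-n2cnc3cc(C(=O)N4CC(C)CC(C)C4)ccc32)c1`, gives 271 nM in this assay, and the two values sit within the usual scatter of each other. For the measured compounds named here, the one measured step, a 1.4-fold higher number from compound 1 to compound 2 (0.15 log units; within the scatter), swapped one ring on the carbonyl carbon for another and produced no change beyond the scatter.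

Compound 3 `CCCCNC(=O)c1ccc2c(c1)ncn2-c1cccc(C)c1` is not yet measured. The change is butylamino in place of pyrrolidin-1-yl on a carbonyl carbon; the ring is opened into a chain of the same size that now carries a hydrogen-bond donor. Going by the values given here, the single step that bears on it only shows that a ring swap at this carbonyl left the number where it was, and nothing here tells how an open chain with a donor behaves. Compound 3 is therefore expected to land close to compound 2, with a step of a 1.3-fold higher number from compound 2 to compound 3 (0.12 log units; within the scatter) that may well stay inside the scatter. The estimate for compound 3 is 500 nM, within 180 nM to 1500 nM.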

Compound 3, half-maximal inhibitory concentration: 1360 nM
Compound 3: middle estimate off by 2.7-fold (0.43 log units), on the low side, and the stated range covers the measured number.
By their numbers in this assay, from the lowest: compounds 1 and 2 (each within the scatter of the next); then compound 3.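

In this assay, this position on the carbonyl carbon proves sensitive to what sits there: butylamino in place of pyrrolidin-1-yl gives a 3.6-fold higher number from compound 2 to compound 3 (0.55 log units; beyond the scatter) and butylamino in place of 3,5-dimethylpiperidin-1-yl gives a 5.0-fold higher number from compound 1 to compound 3 (0.70 log units; beyond the scatter) in the same direction. The earlier swap of one ring for another stayed within the scatter, whereas here the two compounds with a ring both give lower numbers than the open chain, which also brings a hydrogen-bond donor. Nothing available explains this rise.

Compound 3 loses the ring and gains the amide hydrogen in one change, so the compounds shown cannot tell which of the two matters. An open chain without that hydrogen, such as N-butyl-N-methylamino, would separate them.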